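Indole acrylonitrile series: fluoro to methoxy on the indole

The compounds below may be only part of what the source reports. "The series", "measured", "known", "first", "only" and "open" are said of these compounds alone.

Measured compounds:
compound 1 `N#C/C(=C\c1c[nH]c2cc(F)ccc12)C(=O)c1c[nH]c2cc(F)ccc12`, > 50000 nM
compound 2 `N#C/C(=C\c1cn(Cc2ccc(Cl)cc2)c2ccccc12)C(=O)c1c[nH]c2cc(F)ccc12`, 16600 nM
compound 3 `COc1ccc2c(C(=O)/C(C#N)=C/c3c[nH]c4cc(F)ccc34)c[nH]c2c1`, > 50000 nM

In a functional assay on MIA PaCa-2 cells (Homo sapiens) for cytotoxicity, read by WST assay, with a stated time of 48 h (a higher number here means a weaker inhibitor, a lower number a stronger inhibitor), compound 1 gives > 50000 nM, which is a limit of the assay and not a number. Compound 3 likewise gives > 50000 nM in this assay, again a limit. The change between them, (methoxy in place of fluoro on an aromatic carbon), therefore gives a step that the two limits leave unreadable from compound 1 to compound 3; both values sit at the limit of > 50000 nM in this assay, at which 2 of the 3 values shown sit. For the measured compounds named here, compound 2 in this assay gives 16600 nM, the only number among the three. How the core of compound 2 differs from the core of compound 1 is not broken down here.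

Compound 4 `COc1ccc2c(C(=O)/C(C#N)=C/c3cn(Cc4ccc(Cl)cc4)c4ccccc34)c[nH]c2c1` is not yet measured. It differs from compound 2 by methoxy in place of fluoro on an aromatic carbon, the same change as from compound 1 to compound 3, and both changes sit at the same place. Since that earlier step is unreadable, the expected step of a 1.3-fold higher number from compound 2 to compound 4 (0.12 log units; within the scatter) is set near zero with wide bounds. Compound 4 is estimated at 22000 nM in this assay, with a range from 8000 nM to 60000 nM.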

Compound 4, half-maximal inhibitory concentration: 40400 nM
The estimate for compound 4 lay 1.8-fold (0.26 log units) below the measured number; low and high end bracket the measured number.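

In this assay, replacing 6-fluoro-1H-indol-3-yl with 6-methoxy-1H-indol-3-yl gives a 2.4-fold higher number from compound 2 to compound 4 (0.39 log units; beyond the scatter), a modest step that is readable on the core of compound 2. The same change on the core of compound 1 cannot be read, because compound 1 and compound 3 both sit at a limit of the assay, not at a number: the limit of > 50000 nM in this assay, at which 2 of the 4 values shown sit. The series therefore gives one readable step on one core, which shows the direction and size of the change there but does not show whether that step carries over to another core.

On these data alone, the comparison at this place covers only fluoro and methoxy, so it remains open how an amine or a carboxylic acid on the same aromatic carbon would read on the core of compound 2. As far as these compounds go, it also remains open whether a longer chain, such as ethoxy, would continue the step seen with methoxy.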